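Replacing the chloro of compound 3 with a carbamate-bearing chain

A few compounds are considered here, and "the series" means these few. Any claim that something is new, unique, unknown or untested is made for them only; others in the source may bear on it.

Of the compounds shown here, three sharing one core have been tested in a functional assay on the whole organism with Rattus norvegicus as the target, with a stated time of 4 h, at a dose of 40 mg/kg by the intraperitoneal route; on this read-out higher numbers stand for more inhibition at the one dose given (going by the name of the read-out) and lower numbers for less inhibition. Compound 1 `CSCc1c(C)nc2c(OCc3ccccc3)cccn12` gives 29%, compound 2 `Cc1nc2c(OCc3ccccc3)cccn2c1C[S+](C)[O-]` gives 0%, and compound 3 `Cc1nc2c(OCc3ccccc3)cccn2c1Cl` gives 93%, the highest of the three numbers, with compound 1 nearest to it and compound 2 furthest.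

The next compound, compound 4 `Cc1nc2c(OCc3ccccc3)cccn2c1COC(=O)N(C)C`, differs from compound 3 in one place: ((dimethylcarbamoyl)oxy)methyl in place of chloro on an aromatic carbon.

For the measured compounds named here, two measured steps bear on this change, since both replace a chain group on that aromatic carbon with chloro. The step from compound 1 to compound 3, chloro in place of (methylsulfanyl)methyl, was a number 64 percentage points higher from compound 1 to compound 3 (beyond the scatter); the step from compound 2 to compound 3 was a number 93 percentage points higher from compound 2 to compound 3 (beyond the scatter). Compound 4 goes the other way, putting a chain group back in place of chloro, so a fall beyond the scatter in this assay is expected. Compound 4 is therefore estimated at 30%, within 5% to 65%, which would mean an expected step of a number 63 percentage points lower from compound 3 to compound 4 (beyond the scatter).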

Compound 4, a percentage reported as inhibition, in the whole organism at one dose (the size of the read-out at that dose, not a potency): 75%
Beside the measured number, compound 4's estimate is 45 percentage points below it; measured number outside the range, above it.
By their numbers in this assay, from the lowest: compound 2; then compound 1; then compound 4; then compound 3.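

Chloro is not the only group on this aromatic carbon that keeps much of the inhibition in this assay: the change to ((dimethylcarbamoyl)oxy)methyl gives a number 18 percentage points lower from compound 3 to compound 4 (beyond the scatter). A chain on this carbon therefore need not bring a low number, and what the chain carries on its saturated carbon decides much of the outcome, with (dimethylcarbamoyl)oxy in place of methylsulfanyl giving a number 46 percentage points higher from compound 1 to compound 4 (beyond the scatter) and the exchange for the group of compound 2 giving a number 75 percentage points higher from compound 2 to compound 4 (beyond the scatter). No measurement here bears on why these groups differ so widely.

As far as these compounds go, it remains open how an amine or a carboxylic acid on that saturated chain carbon would read in this assay. Also open, from the compounds shown here alone, is whether a longer chain leading to the carbamate would hold the number.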